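Trifluoromethyl in place of cyclopropyl on compound 3

This account rests on a few compounds, and the source may have more. Where it says the series, first, only, none or still open, it means among the compounds named here.

Measured so far in a physicochemical assay for lipophilicity; a higher number here means a more lipophilic compound, a lower number a more polar compound:
- compound 1 `Cc1cc(-c2noc([C@H](C)NC(=O)c3cc(C(F)(F)F)nn3C)n2)ccn1`: 3.3
- compound 2 `COc1cc(-c2noc([C@H](C)NC(=O)c3cc(C(F)(F)F)nn3C)n2)ccn1`: 3.4
- compound 3 `C[C@H](NC(=O)c1cc(C(F)(F)F)nn1C)c1nc(-c2ccnc(C3CC3)c2)no1`: 4.1

Of these three, compound 3 stands highest in this assay, at 4.1. The gap between the other two is small, with a number 0.10 log units higher from compound 1 to compound 2 (within the scatter). Compound 3 clears both of them: the records show a number 0.80 log units higher from compound 1 to compound 3 (beyond the scatter), and also a number 0.70 log units higher from compound 2 to compound 3 (beyond the scatter).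

The next compound, compound 4 `C[C@H](NC(=O)c1cc(C(F)(F)F)nn1C)c1nc(-c2ccnc(C(F)(F)F)c2)no1`, carries trifluoromethyl in place of cyclopropyl on an aromatic carbon, next to the ring nitrogen (trifluoromethyl in place of cyclopropyl on an aromatic carbon). The two steps into compound 3 bear on this change, since they act at the same place and both involve cyclopropyl. Neither involves trifluoromethyl, however, so they show how far this place can move the number but give no direction for this exchange. The forecast therefore stays close to compound 3, with only a slight fall and no shift beyond the scatter. The expected step is a number 0.10 log units lower from compound 3 to compound 4 (within the scatter). For compound 4 the estimated value is 4, with an expected range from 3.6 to 4.4.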

Compound 4, distribution coefficient: 3.6
The estimate for compound 4 lay 0.40 log units above the measured number; low and high end bracket the measured number.
By their numbers in this assay, from the lowest: compounds 1, 2 and 4 (each within the scatter of the next); then compound 3.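

In this assay, this position now shows that the exchange of cyclopropyl for trifluoromethyl moves the number beyond the scatter, with a number 0.50 log units lower from compound 3 to compound 4 (beyond the scatter). Trifluoromethyl does not separate from methoxy, with a number 0.20 log units higher from compound 2 to compound 4 (within the scatter), or from methyl, with a number 0.30 log units higher from compound 1 to compound 4 (within the scatter), so among the four groups seen at this place only cyclopropyl stands apart. Nothing measured here accounts for the step from cyclopropyl to trifluoromethyl.

From the compounds shown here alone, whether an open chain such as isopropyl would stand with cyclopropyl or with the other three groups remains open, as does where an amine or a nitrile would fall at this place. The compounds shown vary only this one place, so whether the step keeps its size on another core also stays unknown.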